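The compounds below may be only part of what the source reports. "The series", "measured", "known", "first", "only" and "open" are said of these compounds alone.

Measured compounds:
compound 1, `CCc1ccc(-c2nc3c(c(C)nn3-c3ccccc3)c(-c3ccccc3Br)c2C#N)cc1`, 1500 nM;
compound 2, `CCc1ccc(-c2nc3c(c(C)nn3-c3ccccc3)c(-c3ccccc3C(=O)O)c2C#N)cc1`, 33000 nM;
compound 3, `Cc1nn(-c2ccccc2)c2nc(-c3ccc(C(C)C)cc3)c(C#N)c(-c3ccccc3O)c12`, 9800 nM.

In a physicochemical assay for solubility, read by spectrophotometry, in phosphate buffer, with a stated time of 18 h, at pH 7.4 (on this read-out higher numbers stand for higher solubility and lower numbers for lower solubility), compound 3 gives 9800 nM, the second highest of the three numbers. Its nearest neighbour is compound 2, which gives 33000 nM in this assay, and the furthest is compound 1, which gives 1500 nM. Among the compounds with values here, the one measured step, a 22-fold higher number from compound 1 to compound 2 (1.34 log units; beyond the scatter), concerns the group on the 2-substituted phenyl ring and therefore does not touch the position altered here.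

Compound 4, `Cc1nn(-c2ccccc2)c2nc(-c3ccc4c(c3)OCCO4)c(C#N)c(-c3ccccc3O)c12`, differs from compound 3 in one place: 2,3-dihydro-1,4-benzodioxin-6-yl in place of 4-isopropylphenyl on an aromatic carbon. The group that enters carries two hydrogen-bond acceptors where the group that leaves carries none, and it sits next to the ring nitrogen and ortho to the cyano group. No measured pair in this set changes that position, so the expectation rests on the change itself rather than on a shown step. A modest rise in this assay is expected, a 2.0-fold higher number from compound 3 to compound 4 (0.31 log units; beyond the scatter), though it may well fall within the scatter. Compound 4 is accordingly estimated at 20000 nM in this assay, with a range from 7000 nM to 60000 nM.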

Compound 4, solubility: 11000 nM
Estimate against measurement, compound 4: 1.8-fold (0.26 log units) above, within the range that was stated.
By their numbers in this assay, from the lowest: compound 1; then compounds 3 and 4 (each within the scatter of the next); then compound 2.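

Placing 2,3-dihydro-1,4-benzodioxin-6-yl in place of 4-isopropylphenyl, on the aromatic carbon next to the ring nitrogen and ortho to a cyano group, gives a 1.1-fold higher number from compound 3 to compound 4 (0.05 log units; within the scatter) in this assay. Within the data shown here, this is the first reading at this position, and it shows that this exchange, which brings in hydrogen-bond acceptors and a non-aromatic ring with two oxygens, does not separate the two compounds on this read-out. Among these compounds, the only earlier step, carboxy in place of bromo at another place on the core, was of a different order, a 22-fold higher number from compound 1 to compound 2 (1.34 log units; beyond the scatter), so the set now holds one change that separates its pair and one that does not. No measurement shown here offers an explanation for this result.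

From the compounds shown here alone, what remains open is whether a group of another kind at this position, such as an aryl ring carrying an amine or a carboxylic acid, would give a number beyond the scatter of compound 3. Going by these compounds, it is also open whether the same exchange would read alike with a carboxy or bromo group in place of the hydroxy on the 2-hydroxyphenyl group.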